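From Cyclopentyloxy to Phenoxy: One Swap, One Estimate

The source may hold more compounds than are shown below. What is called first, only, known or untested is meant among the compounds shown, and "the series" means these compounds.

Of the compounds shown here, two have been measured so far. Compound 1 `Cc1cc(-c2ccccc2)c(S(C)(=O)=O)cc1C(=O)N=C(N)N` carries a phenyl group, and in a functional assay for inhibition of sodium/hydrogen exchanger (Oryctolagus cuniculus) (a higher number here means a weaker inhibitor, a lower number a stronger inhibitor), compound 1 gives 19 nM. Compound 2 `Cc1cc(OC2CCCC2)c(S(C)(=O)=O)cc1C(=O)N=C(N)N` carries a cyclopentyloxy group in its place, and in this assay compound 2 gives 27 nM. The step of a 1.4-fold higher number from compound 1 to compound 2 (0.15 log units; within the scatter) shows that exchanging these two groups leaves the result essentially unchanged. Compound 2 thus stands alongside compound 1 among the two numbers recorded, the pair lying within the scatter of each other, so no order between them can be claimed.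

Compound 3 `Cc1cc(Oc2ccccc2)c(S(C)(=O)=O)cc1C(=O)N=C(N)N` has not been measured. It differs from compound 2 by phenyl in place of cyclopentyl on an oxygen on an aromatic ring; cut one bond further out, the change reads cyclopentyloxy to phenoxy. Within the data shown here, only one measured step bears on this: a 1.4-fold higher number from compound 1 to compound 2 (0.15 log units; within the scatter), which exchanged a phenyl for a cyclopentyloxy on an aromatic carbon and stayed within the scatter. Given that, the expected step of a 1.1-fold lower number from compound 2 to compound 3 (0.03 log units; within the scatter) is none beyond the scatter. Compound 3 is therefore estimated at 25 nM, with a range from 10 nM to 60 nM.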

Compound 3, half-maximal inhibitory concentration: 10 nM
The estimate for compound 3 lay 2.5-fold (0.40 log units) above the measured number; the range from low to high includes it.
By their numbers in this assay, from the lowest: compounds 3, 1 and 2 (each within the scatter of the next, the first and the last beyond it).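

The ring on this oxygen does make a difference: exchanging cyclopentyl for phenyl gives a 2.7-fold lower number from compound 2 to compound 3 (0.43 log units; beyond the scatter) in this assay and is the only step among these three compounds that clears the scatter, although only modestly. The same comparison also links the two phenyl-bearing compounds, and the change from a phenyl on the aromatic carbon to a phenoxy there gives a 1.9-fold lower number from compound 1 to compound 3 (0.28 log units; within the scatter) and so does not separate them, which means that adding the oxygen to the phenyl group cannot be said to shift the number. Nothing available here explains why phenyl on this oxygen gives a lower number than cyclopentyl.

The step from cyclopentyl to phenyl alters ring size and aromatic character together, so these compounds cannot show which of the two matters, and a cyclohexyl on the same oxygen would help to pull them apart. Also open, as far as these compounds go, is whether a chlorine or a methoxy group on the phenyl ring, or an amine in place of the oxygen, would move the number further in either direction.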